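Adding a fluoro group beside the bromo of compound 3

A few compounds are considered here, and "the series" means these few. Any claim that something is new, unique, unknown or untested is made for them only; others in the source may bear on it.

Of the compounds shown here, three have been measured in an assay on isolated protein for inhibition of Indoleamine 2,3-dioxygenase 1 (Homo sapiens), read by spectrophotometry, with a stated time of 1 h; on this read-out lower numbers stand for stronger inhibition and higher numbers for weaker inhibition. Compound 3 `O=[N+]([O-])c1ccc(N/C(=N\O)c2cccc(Br)c2)c2nonc12` gives 105 nM in this assay, compound 1 `O=[N+]([O-])c1ccc(N/C(=N\O)c2ccccc2Cl)c2nonc12` gives 135 nM, and compound 2 `O=[N+]([O-])c1ccc(N/C(=N\O)c2ccccc2Br)c2nonc12` gives 80 nM. Among these three numbers compound 3 stands second highest, and every step between them is small: a 1.3-fold lower number from compound 1 to compound 3 (0.11 log units; within the scatter), and a 1.3-fold higher number from compound 2 to compound 3 (0.12 log units; within the scatter). The remaining step, a 1.7-fold lower number from compound 1 to compound 2 (0.23 log units; within the scatter), also stays within the scatter.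

Compound 4 `O=[N+]([O-])c1ccc(N/C(=N\O)c2ccc(F)c(Br)c2)c2nonc12` differs from compound 3 by fluoro in place of hydrogen on an aromatic carbon: the bromo group of compound 3 is retained, and a fluoro group enters ortho to it, para to the large group, so that 3-bromophenyl becomes 3-bromo-4-fluorophenyl. Among the compounds with values here, none of the measured steps adds a second halogen to a ring that already carries one; each either exchanges bromo for chloro or moves a bromo to another position of the ring, and none moves the number beyond the scatter. Within the data shown here, with no closer precedent, a step of about the same small size is expected, a 1.1-fold lower number from compound 3 to compound 4 (0.02 log units; within the scatter), with no direction the data can support. Compound 4 is therefore estimated at 100 nM, with a range from 50 nM to 200 nM.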

Compound 4, half-maximal inhibitory concentration: 92 nM
For compound 4 the middle estimate is 1.1-fold (0.04 log units) above the measured one; the range from low to high includes it.
By their numbers in this assay, from the lowest: compounds 2, 4, 3 and 1 (each within the scatter of the next).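

In this assay, within the data shown here, fluoro in place of hydrogen on an aromatic carbon, ortho to a bromo group and para to the large group, gives a 1.1-fold lower number from compound 3 to compound 4 (0.06 log units; within the scatter), which shows that a second halogen can enter a ring already carrying one without moving the number beyond the scatter, a change that no earlier step covered. The 3-bromo-4-fluorophenyl group also stays level with the two groups that carry a single halogen: there is a 1.2-fold higher number from compound 2 to compound 4 (0.06 log units; within the scatter) and a 1.5-fold lower number from compound 1 to compound 4 (0.17 log units; within the scatter), so this change opens no measurable separation among the four compounds. Nothing available on these compounds offers an explanation for this result.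

Every ring group shown carries only halogens, so it remains open whether this place para to the large group would accept an amine, a carboxylic acid, a methoxy group or a longer chain with an equally small step. From the compounds shown here alone, it is also open whether fluoro would give a step of the same size on a ring without the bromo group, or on the 2-bromophenyl and 2-chlorophenyl rings of the other two compounds.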